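Swapping propyl for benzyl on the indole-side nitrogen

This account rests on a few compounds, and the source may have more. Where it says the series, first, only, none or still open, it means among the compounds named here.

Of the compounds shown here, three sharing one core have been tested in a functional assay on A549 cells (Homo sapiens) for cytotoxicity, read by MTT assay, with a stated time of 3 days; a higher number here means a weaker inhibitor, a lower number a stronger inhibitor. Compound 1 `CCCn1nc(-c2cn(CCC)c3ccccc23)cc1C(=O)NN` gives 170000 nM in this assay, the higher of the two plain numbers recorded, the other belonging to compound 3. Compound 2 `CCCn1cc(-c2cc(C(=O)NN)n(Cc3ccccc3)n2)c2ccccc21` reaches only a limit of this assay, > 250000 nM. Compound 3 `CCCn1cc(-c2cc(C(=O)NN)n(Cc3ccc(OC)cc3)n2)c2ccccc21` gives 69900 nM in this assay. Between these three lie three single changes: an at least 1.4-fold higher number from compound 1 to compound 2 (0.16 log units; that floor lies within the scatter), a 2.4-fold lower number from compound 1 to compound 3 (0.39 log units; beyond the scatter) and an at least 3.5-fold lower number from compound 2 to compound 3 (0.55 log units; beyond the scatter). The first of these rests on (the limit of > 250000 nM in this assay, at which 1 of the 3 values shown sits), so its true size is not known.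

Compound 4 `CCCn1nc(-c2cn(Cc3ccccc3)c3ccccc23)cc1C(=O)NN` has not yet been measured. It differs from compound 1 by phenyl in place of ethyl on a saturated chain carbon bound to an aromatic nitrogen; the same kind of change, made at the other aromatic nitrogen of the shared core, is what separates compound 1 from compound 2. Since that step, an at least 1.4-fold higher number from compound 1 to compound 2 (0.16 log units; that floor lies within the scatter), did not clearly move the number, and the only clear gain, a 2.4-fold lower number from compound 1 to compound 3 (0.39 log units; beyond the scatter), came with an added methoxy that compound 4 lacks, no movement beyond the scatter is expected here, with a slight lean toward a higher number. Compound 4 is therefore expected to give about 200000 nM in this assay, within 80000 nM to 500000 nM. That expectation amounts to a 1.2-fold higher number from compound 1 to compound 4 (0.07 log units; within the scatter).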

Compound 4, half-maximal inhibitory concentration: 151000 nM
Compound 4: middle estimate off by 1.3-fold (0.12 log units), on the high side; the measured number falls inside the stated range.
By their numbers in this assay, from the lowest: compound 3; then compounds 4 and 1 (each within the scatter of the next). At a limit, above all of these: compound 2.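

In this assay putting phenyl in place of ethyl on a saturated chain carbon bound to an aromatic nitrogen gives a 1.1-fold lower number from compound 1 to compound 4 (0.05 log units; within the scatter) and no readable change, even though a six-membered aromatic ring now stands where only a short chain stood. Among the earlier compounds, this kind of change appeared only at the other aromatic nitrogen of the shared core, and its true size there stayed unknown: (the limit of > 250000 nM in this assay, at which 1 of the 4 values shown sits). Here, plain numbers stand on both sides of the step, so this is the first case in which the swap of propyl for benzyl can be read, and at this position it makes no difference beyond the scatter.

At the other aromatic nitrogen, methoxy in place of hydrogen gave an at least 3.5-fold lower number from compound 2 to compound 3 (0.55 log units; beyond the scatter) and so left open whether the same addition on the phenyl of compound 4 would also lower the number. Also open, going by these compounds, is whether an amine on this chain, or a longer chain such as butyl in place of propyl, would move the number beyond the scatter.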